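The compounds below may be only part of what the source reports. "The series", "measured", "known", "first", "only" and "open" are said of these compounds alone.

In an in vitro functional assay on cells for agonist activity at Bombesin receptor subtype-3 (Homo sapiens), read by luminescence and calcium flux (on this read-out higher numbers stand for an effect only at larger amounts of compound and lower numbers for an effect already at smaller amounts), compound 1 `CCCCc1cnc(C(CCC)Cc2ccc(-c3ccccc3C(=O)O)cc2)[nH]1` gives 1180 nM.
Compound 2 `CCCCc1cnc(CCCc2ccc(-c3ccccc3C(=O)O)cc2)[nH]1` gives 5600 nM.
Compound 3 `O=C(O)c1ccccc1-c1ccc(CCc2ncc(Cc3ccc(Cl)cc3)[nH]2)cc1` gives 2290 nM.

Compound 3 and compound 1 sit within the scatter of one another, so no order can be read between them; compound 2, by contrast, gives a higher number than compound 3, and that gap lies beyond the scatter. Compound 4 `O=C(O)c1ccccc1-c1ccc(CCc2ncc(CC3CCCCCC3)[nH]2)cc1` has not been measured. It differs from compound 3 in one place: cycloheptyl in place of 4-chlorophenyl on a saturated chain carbon bound to an aromatic carbon. For the measured compounds named here, no measured pair shows an exchange of this kind, so the expectation rests on compound 3 alone. A small step, toward a somewhat higher number, is expected: a 1.4-fold higher number from compound 3 to compound 4 (0.15 log units; within the scatter). For compound 4 in this assay the estimate is 3200 nM, within a range from 900 nM to 12000 nM.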

Compound 4, half-maximal effective concentration: 88 nM
The estimate for compound 4 lay 36-fold (1.56 log units) above the measured number; the measured number lies below the stated range.
By their numbers in this assay, from the lowest: compound 4; then compounds 1 and 3 (each within the scatter of the next); then compound 2.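

Replacing 4-chlorophenyl with cycloheptyl on a saturated chain carbon bound to an aromatic carbon gives a 26-fold lower number from compound 3 to compound 4 (1.42 log units; beyond the scatter) in this assay. This position is therefore highly sensitive to which ring it carries, even though both groups have 7 heavy atoms. An aromatic ring bearing chlorine is not required here, since a non-aromatic ring of carbon only does far better. Nothing available accounts for the size of this step.

Still open, as far as these compounds go, is whether the gain comes from the seven-membered ring itself, from the absence of chlorine, or from the absence of an aromatic ring. Plain phenyl or cyclohexyl at this position would help separate these possibilities.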